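This account rests on a few compounds, and the source may have more. Where it says the series, first, only, none or still open, it means among the compounds named here.

Compound 1 `O=C(Nc1ccc(Cl)cc1)Nc1ccc(C(=O)/C=C/c2ccccc2)cc1` gives 74.6% in a functional assay on the whole organism (Abdomen, strain Swiss) for inhibition, with Mus musculus as the target, with a stated time of 30 min, at a dose of 10 mg/kg by the intraperitoneal route; a lower number here means less inhibition, a higher number more inhibition at the dose given (going by the name of the read-out).
Compound 2 `O=C(Nc1ccc(Cl)cc1)Nc1ccc(C(=O)/C=C/c2ccc(Cl)c(Cl)c2)cc1` gives 21.6% in this assay.
Compound 3 `O=C(/C=C/c1ccccc1)c1ccc(NC(=S)Nc2ccc(Cl)cc2)cc1` gives 94.5% in this assay.

Compound 2 stands lowest of the three in this assay, beyond the scatter below both compound 1 and compound 3. Compound 4 `COc1ccc(/C=C/C(=O)c2ccc(NC(=O)Nc3ccc(Cl)cc3)cc2)cc1` differs from compound 2 in one place: 4-methoxyphenyl in place of 3,4-dichlorophenyl on a double-bonded chain carbon bound to a double-bonded chain carbon. Within the data shown here, the only measured step at this position, a number 53 percentage points lower from compound 1 to compound 2 (beyond the scatter), shows that putting 3,4-dichlorophenyl in place of phenyl cost a large amount of inhibition; compound 4 removes that 3,4-dichlorophenyl again, which suggests a recovery, but no measured compound carries 4-methoxyphenyl, so the size is uncertain. The step of a number 38.4 percentage points higher from compound 2 to compound 4 (beyond the scatter) is therefore expected to be a clear rise. Compound 4 is estimated at 60%, within 30% to 85%.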

Compound 4, a percentage reported as inhibition, in the whole organism at one dose (the size of the read-out at that dose, not a potency): 84.4%
Compound 4: the middle estimate sits 24.4 percentage points below what was measured; low and high end bracket the measured number.
By their numbers in this assay, from the lowest: compound 2; then compounds 1 and 4 (each within the scatter of the next); then compound 3.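

In this assay, the step of a number 62.8 percentage points higher from compound 2 to compound 4 (beyond the scatter) shows that the loss seen with 3,4-dichlorophenyl does not come with every substituted ring at this position, since 4-methoxyphenyl retains strong inhibition. The step of a number 9.8 percentage points higher from compound 1 to compound 4 (within the scatter) means that methoxy and hydrogen on this aromatic carbon cannot be told apart here. Nothing available explains why the two substituted rings differ so widely.

On these data alone, whether a single chlorine on this ring would behave like the 3,4-dichlorophenyl group or like 4-methoxyphenyl remains open. So does the outcome for an amine or a hydroxy group at the same aromatic carbon.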